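Methylsulfanyl to fluoro on the aromatic ring

A few compounds are considered here, and "the series" means these few. Any claim that something is new, unique, unknown or untested is made for them only; others in the source may bear on it.

In a functional assay on HL-60 cells (Homo sapiens) for antiproliferative activity, read by MTT assay, with a stated time of 72 h (on this read-out lower numbers stand for stronger inhibition and higher numbers for weaker inhibition), compound 2 (`CCOc1ccc(-c2ncnn2-c2cc(OC)c(OC)c(OC)c2)cc1`), which carries ethoxy, gives 20 nM. Compound 3 (`COc1cc(-n2ncnc2-c2ccc(SC)cc2)cc(OC)c1OC`), which carries methylsulfanyl, gives 500 nM, the higher of the two numbers, and the gap between them is a 25-fold higher number from compound 2 to compound 3 (1.40 log units; beyond the scatter). Compound 1 (`COc1cc(-n2ncnc2-c2ccc(Cl)cc2)cc(OC)c1OC`), which carries chloro, reads > 10000 nM, a limit of this assay and not a number.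

Compound 4 (`COc1cc(-n2ncnc2-c2ccc(F)cc2)cc(OC)c1OC`) has fluoro in place of methylsulfanyl on an aromatic carbon, para to a large group: fluoro in place of methylsulfanyl on an aromatic carbon.

All three measured exchanges at this carbon were large. The closest is an at least 20-fold lower number from compound 1 to compound 3 (1.30 log units; beyond the scatter), which replaced chloro with methylsulfanyl, and an at least 500-fold lower number from compound 1 to compound 2 (2.69 log units; beyond the scatter) is larger still. Compound 4 carries a halogen as compound 1 does, so the change from compound 3 is expected to run back toward the limit, on the evidence of an at least 20-fold lower number from compound 1 to compound 3 (1.30 log units; beyond the scatter). For compound 4, the expected step in this assay is large and toward a higher number, estimated as a 10-fold higher number from compound 3 to compound 4 (1.00 log units; beyond the scatter). For compound 4, the estimated value is 5000 nM, with an expected range of 600 nM to 20000 nM.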

Compound 4, half-maximal inhibitory concentration: > 10000 nM
Compound 4: a limit, no number; the forecaster's own chance of this, stated with the estimate: 40%; middle value at least 2.0-fold (0.30 log units) away from the limit.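

Fluoro at this carbon puts the series back at the assay limit in this assay: the exchange for methylsulfanyl gives an at least 20-fold higher number from compound 3 to compound 4 (1.30 log units; beyond the scatter), and the exchange for ethoxy gives an at least 500-fold higher number from compound 2 to compound 4 (2.69 log units; beyond the scatter). Compound 4 gives > 10000 nM, which is a limit and not a number. Among the compounds shown, chloro in compound 1 is no longer the only halogen without a readable number, and the steps between the two compounds at the limit cannot be read: the limit of > 10000 nM in this assay, at which 2 of the 4 values shown sit.

Going by these compounds, how far compound 1 and compound 4 lie past the limit stays unknown, so the two halogens cannot be ranked. On these data alone, whether the ethoxy result depends on the oxygen or on the chain remains open, and propoxy, a longer chain, or dimethylamino, an amine, at this carbon would test it.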